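Removing the aromatic chlorine: what compound 3 might tolerate

The source may report more compounds than this note shows. Statements on the series, on what has been measured and on what is new or still open speak of the compounds shown alone.

Going by the values given here, compound 2 `CC1N=C(S)N(Nc2cccc(Cl)c2)C1C` stands highest of the two numbers so far in a functional assay on MT4 cells (Homo sapiens) for cytotoxicity (a lower number here means that less compound is tolerated, a higher number that more compound is tolerated), giving 259000 nM, while compound 1 `COC(=O)C1N=C(S)N(Nc2cccc(Cl)c2)C1C` gives 48800 nM. Among the compounds with values here, the only measured comparison, a 5.3-fold higher number from compound 1 to compound 2 (0.72 log units; beyond the scatter), concerns a substituent on a saturated ring carbon. Within the data shown here, compound 3 `CC1N=C(S)N(Nc2ccccc2)C1C` differs from compound 2 by hydrogen in place of chloro on an aromatic carbon, a position that no measured step touches. With nothing bearing directly on this change, the expected step is a 1.2-fold higher number from compound 2 to compound 3 (0.06 log units; within the scatter), not beyond the scatter. The estimate for compound 3 in this assay is therefore 300000 nM, within a range of 100000 nM to 800000 nM.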

Compound 3, half-maximal cytotoxic concentration: 181000 nM
Beside the measured number, compound 3's estimate is 1.7-fold (0.22 log units) above it; the measured number falls inside the stated range.
By their numbers in this assay, from the lowest: compound 1; then compounds 3 and 2 (each within the scatter of the next).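

Hydrogen in place of chloro on the aromatic carbon gives a 1.4-fold lower number from compound 2 to compound 3 (0.16 log units; within the scatter) in this assay, so at this position the chloro group can go without a step beyond the scatter, unlike the change on the saturated ring carbon. Nothing at hand explains this result. The compounds shown leave open whether an amine or a carboxylic acid on this aromatic carbon would also stay within the scatter of compound 3. They also leave open whether the same exchange would read alike with the methoxycarbonyl group of compound 1 in place.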